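The source may report more compounds than this note shows. Statements on the series, on what has been measured and on what is new or still open speak of the compounds shown alone.

Measured so far:
compound 1, `CCC(C1CC1)n1nc(C)nc(Nc2c(Cl)cc(C(F)(F)F)cc2Cl)c1=O`: 6.3 nM
compound 2, `COCC(C1CC1)n1nc(C)nc(Nc2c(Cl)cc(C(F)(F)F)cc2Cl)c1=O`: 11 nM
compound 3, `Cc1nc(Nc2cc(C)c(C#N)cc2C)c(=O)n(C(C)C2CC2)n1`: 60 nM

In an assay on isolated protein for displacement of a labelled ligand from corticotropin-releasing factor receptor 1 (Rattus norvegicus) (a higher number here means a weaker inhibitor, a lower number a stronger inhibitor), compound 3 gives the highest of the three numbers, so it is the weakest inhibitor shown; compound 2 comes nearest to it, compound 1 lies furthest away. Compound 4, `CCC(C1CC1)n1nc(C)nc(Nc2cc(C)c(C#N)cc2C)c1=O`, is made from compound 3 by methyl in place of hydrogen on a saturated chain carbon, two bonds along the chain from an aromatic nitrogen and a saturated ring carbon. Among the measured compounds shown here, no measured step repeats this exact change. The only step shown at this chain carbon, a 1.7-fold higher number from compound 1 to compound 2 (0.24 log units; within the scatter), swaps one small group for another and stays within the scatter, which suggests this position tolerates small changes without large shifts. A small move toward a lower number is therefore expected, a 1.3-fold lower number from compound 3 to compound 4 (0.12 log units; within the scatter), but not one clearly beyond the scatter. Compound 4 is estimated at 45 nM, with a range from 20 nM to 110 nM.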

Compound 4, half-maximal inhibitory concentration: 9.3 nM
Compound 4: the middle estimate sits 4.8-fold (0.68 log units) above what was measured; measured number below the stated range.
By their numbers in this assay, from the lowest: compounds 1, 4 and 2 (each within the scatter of the next); then compound 3.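

In this assay, adding a methyl to this saturated chain carbon, which turns 1-cyclopropylethyl into 1-cyclopropylpropyl, gives a 6.5-fold lower number from compound 3 to compound 4 (0.81 log units; beyond the scatter) and so lies beyond the scatter. The position therefore responds to a change of a single carbon, which the step of a 1.7-fold higher number from compound 1 to compound 2 (0.24 log units; within the scatter) at the same carbon did not reveal. No measurement shown gives a reason for this gain.

From the compounds shown here alone, it remains open whether a longer chain or an amine at this carbon would lower the number further. Going by these compounds, it also remains open whether removing this methyl from compound 1 would cost as much.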